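Para-substituted phenyltriazoles: cytotoxicity at the assay limit

The compounds below may be only part of what the source reports. "The series", "measured", "known", "first", "only" and "open" are said of these compounds alone.

Compound 1 `C=C1C[C@]23C[C@@]1(O)CC[C@@H]2c1cccc(C)c1[C@@H]3Cn1cc(-c2ccc(Br)cc2)nn1` carries a bromo group on the pendant ring. In a functional assay on MCF7 cells (Homo sapiens) for cytotoxicity, read by MTT assay, with a stated time of 4 days (on this read-out higher numbers stand for weaker inhibition and lower numbers for stronger inhibition), compound 1 reaches only the limit > 20000 nM. Compound 2 `C=C1C[C@]23C[C@@]1(O)CC[C@@H]2c1cccc(C)c1[C@@H]3Cn1cc(-c2ccccc2)nn1` has hydrogen in its place. In this assay compound 2 likewise reaches only the limit > 20000 nM. The step that the two limits leave unreadable from compound 1 to compound 2 is thus not readable, as the limit of > 20000 nM in this assay, at which 2 of the 2 values shown sit, shows. Compound 3 `C=C1C[C@]23C[C@@]1(O)CC[C@@H]2c1cccc(C)c1[C@@H]3Cn1cc(-c2ccc(F)cc2)nn1` differs from compound 2 by fluoro in place of hydrogen on an aromatic carbon. Among the compounds with values here, the single measured step gives no readable size, so nothing beyond the scatter is expected. The step that the limit leaves unreadable from compound 2 to compound 3 is expected to remain at the limit. Compound 3 is estimated at 30000 nM, within 10000 nM to 100000 nM.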

Compound 3, half-maximal inhibitory concentration: > 20000 nM
Compound 3 ended at the assay's limit; the forecaster's own chance of this, stated with the estimate: 85%; the middle value is on the limit's open side.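

Within the data shown here, no step among compound 1, compound 2 and compound 3 can be read, as all three rest at one limit: the limit of > 20000 nM in this assay, at which 3 of the 3 values shown sit. Going by these compounds, whether bromo, hydrogen and fluoro on the pendant ring differ at all in this assay stays open.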